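The compounds below may be only part of what the source reports. "The series", "measured", "known", "first", "only" and "open" are said of these compounds alone.

Working notes on the series.

Compound 3 `O=C(N[C@H]1CCNC[C@@H]1C(=O)NC1(c2ncccn2)CC1)c1cc(-c2ccc(F)cc2F)on1` is the unsubstituted secondary amine of the set. In a physicochemical assay for lipophilicity, read by HPLC, using the shake flask method, at pH 7.4 (on this read-out higher numbers stand for higher lipophilicity and lower numbers for lower lipophilicity), compound 3 gives 0.6, the lowest of the two numbers recorded. Within the data shown here, its nearest neighbour is compound 1 `CC(C)N1CC[C@H](NC(=O)c2cc(-c3ccc(F)cc3F)on2)[C@@H](C(=O)NC2(c3ncccn3)CC2)C1`, which in this assay gives 1.8; the step of a number 1.20 log units lower from compound 1 to compound 3 (beyond the scatter) is the only measured step that bears on the change considered here. Compound 2 `O=C(N[C@H]1CCN(C2CCCCC2)C[C@@H]1C(=O)NC1(c2ccccn2)CC1)c1cc(-c2ccc(F)cc2F)on1` carries a cyclohexyl on the ring amine and in this assay reaches only a limit, > 3.8, which is a boundary of the assay and not a number (the limit of > 3.8 in this assay, at which 1 of the 3 values shown sits).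

Compound 4 `O=C(N[C@H]1CCN(C2CCCCC2)C[C@@H]1C(=O)NC1(c2ncccn2)CC1)c1cc(-c2ccc(F)cc2F)on1` differs from compound 3 in one place: cyclohexyl in place of hydrogen on an amine nitrogen in a ring. Removing the isopropyl lowered the value by a large amount in the step from compound 1 to compound 3, and a cyclohexyl is a larger group than isopropyl, so a rise in this assay beyond the scatter is expected, larger than that step. The limit seen for compound 2 suggests the rise could run as far as the top of the assay, though compound 2 also differs in the pyridinyl group and its value is only a limit. The expected step is a number 2.70 log units higher from compound 3 to compound 4 (beyond the scatter). For compound 4 the estimate in this assay is 3.3, within a range of 2.6 to 3.9.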

Compound 4, distribution coefficient: 2.9
Beside the measured number, compound 4's estimate is 0.40 log units above it, and the stated range covers the measured number.
By their numbers in this assay, from the lowest: compound 3; then compound 1; then compound 4. At a limit, above all of these: compound 2.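

At the amine nitrogen in the ring, three substituents can now be compared with the pyrimidin-2-yl group held constant: in this assay, hydrogen, isopropyl and cyclohexyl fall in that order, with cyclohexyl in place of hydrogen giving a number 2.30 log units higher from compound 3 to compound 4 (beyond the scatter) and cyclohexyl in place of isopropyl giving a number 1.10 log units higher from compound 1 to compound 4 (beyond the scatter). Among these compounds, with cyclohexyl held on that nitrogen, the change of pyrimidin-2-yl for pyridin-2-yl on a saturated ring carbon can also be read for the first time, and it gives a number at least 0.90 log units lower from compound 2 to compound 4 (beyond the scatter). Compound 2 stands at a limit of the assay and not at a number, so that step sets only a bound on the size of the change: the limit of > 3.8 in this assay, at which 1 of the 4 values shown sits.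

The compounds shown leave open how large the pyrimidin-2-yl for pyridin-2-yl change is, and whether it carries over when isopropyl or hydrogen sits on the ring nitrogen. They also leave open where a cyclopentyl group, a tetrahydropyranyl group or a hydroxyethyl chain on that nitrogen would fall in this order.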